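This account rests on a few compounds, and the source may have more. Where it says the series, first, only, none or still open, it means among the compounds named here.

For the measured compounds named here, compound 2 `Cc1ccc(COc2ccc(-c3nn(CCC#N)c(=S)o3)cc2)cc1` gives 10000 nM in an assay for inhibition of Amine oxidase [flavin-containing] A (Rattus norvegicus) (on this read-out lower numbers stand for stronger inhibition and higher numbers for weaker inhibition), the higher of the two numbers measured; compound 1 `COc1ccc(COc2ccc(-c3nn(CCC#N)c(=S)o3)cc2)cc1` gives 4800 nM in this assay, and the only measured step is a 2.1-fold higher number from compound 1 to compound 2 (0.32 log units; beyond the scatter). Compound 3 `N#CCCn1nc(-c2ccc(OCc3ccc(Cl)cc3)cc2)oc1=S` carries chloro in place of methyl on an aromatic carbon. Going by the values given here, no measured step exchanges methyl for chloro, so the methoxy-to-methyl step offers no direct guide, and the change is expected to stay within the scatter in this assay. Compound 3 is therefore estimated at 8000 nM, between 3000 nM and 25000 nM, a step of a 1.3-fold lower number from compound 2 to compound 3 (0.10 log units; within the scatter).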

Compound 3, half-maximal inhibitory concentration: 2700 nM
Beside the measured number, compound 3's estimate is 3.0-fold (0.47 log units) above it; measured number below the stated range.
By their numbers in this assay, from the lowest: compounds 3 and 1 (each within the scatter of the next); then compound 2.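

On the aromatic carbon that carries methyl in compound 2, chloro gives a 3.7-fold lower number from compound 2 to compound 3 (0.57 log units; beyond the scatter) in this assay and so shows that this position responds to a second exchange, not only to methoxy. Chloro in place of methoxy gives a 1.8-fold lower number from compound 1 to compound 3 (0.25 log units; within the scatter) and so leaves compound 3 and compound 1 level, with methyl alone apart from them. Nothing at hand accounts for this order. On these data alone, how bromo, fluoro, an amine or a carboxylic acid would read at this carbon remains open, as does whether the pattern holds with another chain in place of the nitrile-bearing one on the shared core.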